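Swapping an isopropyl for fluorine on the phenyl ring

This account rests on a few compounds, and the source may have more. Where it says the series, first, only, none or still open, it means among the compounds named here.

Two urea-linked compounds with a shared core have been tested in a functional assay on HepG2 cells (Homo sapiens) for inhibition, read by MTT assay, with a stated time of 72 h; on this read-out lower numbers stand for stronger inhibition and higher numbers for weaker inhibition. Compound 1 `CC(C)c1ccccc1-n1cc(COc2cccc(NC(=O)Nc3ccc(Cl)c(C(F)(F)F)c3)c2)nn1` gives 1900 nM in this assay. Compound 2 `CC(C)c1ccc(-n2cc(COc3cccc(NC(=O)Nc4ccc(Cl)c(C(F)(F)F)c4)c3)nn2)cc1` gives 2470 nM in this assay, which is the higher of the two numbers, though the step of a 1.3-fold higher number from compound 1 to compound 2 (0.11 log units; within the scatter) lies within the scatter, so the two compounds cannot be told apart on these data.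

Compound 3 `O=C(Nc1cccc(OCc2cn(-c3ccc(F)cc3)nn2)c1)Nc1ccc(Cl)c(C(F)(F)F)c1` is not yet measured. Compared with compound 2 it carries the change (fluoro in place of isopropyl on an aromatic carbon), which at one bond further out reads 4-isopropylphenyl to 4-fluorophenyl. For the measured compounds named here, no measured step covers this exchange; the only step available, from compound 1 to compound 2, moved the isopropyl group around the ring without changing the number beyond the scatter. That gives no direct guide to replacing the group by fluoro, so the expectation is loosely anchored and wide.

On this basis compound 3 is expected to give about 3000 nM in this assay, with a range from 1200 nM to 7500 nM, meaning an expected step of a 1.2-fold higher number from compound 2 to compound 3 (0.08 log units; within the scatter) that may well stay within the scatter.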

Compound 3, half-maximal inhibitory concentration: 1350 nM
Estimate against measurement, compound 3: 2.2-fold (0.35 log units) above; the range from low to high includes it.
By their numbers in this assay, from the lowest: compounds 3, 1 and 2 (each within the scatter of the next).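

In this assay, replacing the isopropyl, para to a large group, with a fluoro gives a 1.8-fold lower number from compound 2 to compound 3 (0.26 log units; within the scatter), so the 3 heavy atoms of the isopropyl can give way to a single fluorine without a change that can be told apart from the scatter. Compound 1 offers a second comparison, in which the 4-fluorophenyl group takes the place of the 2-isopropylphenyl group and gives a 1.4-fold lower number from compound 1 to compound 3 (0.15 log units; within the scatter); the earlier pair showed only that the isopropyl could sit at a different place on the ring, whereas these steps show that the read-out also stays within the scatter when that group is exchanged for a much smaller one. No measurement is available to explain these results.

The compounds shown leave open whether a different kind of group at this place, such as an amine, a carboxylic acid or a longer chain, would shift the number beyond the scatter. They also leave open how a 2-fluorophenyl group would compare with the 2-isopropylphenyl group of compound 1.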